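This account rests on a few compounds, and the source may have more. Where it says the series, first, only, none or still open, it means among the compounds named here.

Compound 1, `COc1cc(-c2nnc(SCC(=O)c3ccc(C)cc3)n2N)cc(OC)c1OC`: 370 nM
Compound 2, `COc1cc(-c2nnc(SCC(=O)c3cccc(Br)c3)n2N)cc(OC)c1OC`: 5320 nM

Both numbers come from a functional assay on HCT-116 cells (Homo sapiens) for antiproliferative activity, read by MTT assay, with a stated time of 48 h; a higher number here means a weaker inhibitor, a lower number a stronger inhibitor. Compound 1 has the lowest of the two numbers; its nearest neighbour is compound 2, reached by a 14-fold higher number from compound 1 to compound 2 (1.16 log units; beyond the scatter). Compound 3, `COc1cccc(NC(=O)CSc2nnc(-c3cc(OC)c(OC)c(OC)c3)n2N)c1`, has not been measured. It differs from compound 1 in one place: (3-methoxyphenyl)amino in place of 4-methylphenyl on a carbonyl carbon. Going by the values given here, the one measured step also changes the group on the carbonyl carbon and was large in the weakening direction, although the group entering there was a different one, so it is only a rough guide. A weakening step is therefore expected for compound 3 , a 4.1-fold higher number from compound 1 to compound 3 (0.61 log units; beyond the scatter), with wide uncertainty. Compound 3 is estimated at 1500 nM, between 400 nM and 6000 nM.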

Compound 3, half-maximal inhibitory concentration: 680 nM
The estimate for compound 3 lay 2.2-fold (0.34 log units) above the measured number; the measured number falls inside the stated range.
By their numbers in this assay, from the lowest: compounds 1 and 3 (each within the scatter of the next); then compound 2.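

The carbonyl carbon is not limited to a carbon-linked aryl group: placing (3-methoxyphenyl)amino there in place of 4-methylphenyl gives a 1.8-fold higher number from compound 1 to compound 3 (0.26 log units; within the scatter), so the two compounds cannot be told apart. In place of 3-bromophenyl, the same group gives a 7.8-fold lower number from compound 2 to compound 3 (0.89 log units; beyond the scatter), which shows that a change at this position need not weaken the compound as the earlier step did.

On these data alone, what a plain phenylamino group or a saturated amine such as morpholine would do on this carbonyl carbon stays open. No available measurement explains these differences.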